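The source may hold more compounds than are shown below. What is called first, only, known or untested is meant among the compounds shown, and "the series" means these compounds.

Measured so far in a physicochemical assay for solubility, in phosphate buffer, measured as kinetic solubility, with a stated time of 1 h, at pH 7.4; a higher number here means a more soluble compound, a lower number a less soluble compound:
compound 2 `COc1ccc2nc(C)cc(OCC(=O)Nc3ccccc3)c2c1`: 63000 nM
compound 3 `COc1ccc2nc(C)cc(OCC(=O)Nc3ccc(Cl)c(C(F)(F)F)c3)c2c1`: 17000 nM
compound 1 `CCOc1ccc2nc(C(F)(F)F)cc(OCC(=O)Nc3cc(C)cc(C)c3)c2c1`: < 1000 nM, a limit of the assay and not a number

Compound 2 stands highest of the two numbers in this assay; compound 3 sits lower by a gap beyond the usual scatter. Compound 1 sits at the limit of < 1000 nM in this assay, at which 1 of the 3 values shown sits.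

Compound 4 `COc1ccc2nc(C)cc(OCC(=O)Nc3ccncc3)c2c1` has not yet been measured. It differs from compound 2 in one place: pyridin-4-yl in place of phenyl on an amide-type nitrogen. For the measured compounds named here, no measured pair shows this change, so its size is open; in this assay an upward step of modest size, beyond the scatter, is expected. Compound 4 is expected to give about 120000 nM, within 50000 nM to 300000 nM. The expected step is a 1.9-fold higher number from compound 2 to compound 4 (0.28 log units; within the scatter).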

Compound 4, solubility: 91500 nM
For compound 4 the middle estimate is 1.3-fold (0.12 log units) above the measured one; the measured number falls inside the stated range.
By their numbers in this assay, from the lowest: compound 3; then compounds 2 and 4 (each within the scatter of the next). At a limit, below all of these: compound 1.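

For the compounds shown here, compound 2 and compound 4 form the first pair here that differs in one place, and in this assay pyridin-4-yl in place of phenyl on the amide-type nitrogen gives a 1.5-fold higher number from compound 2 to compound 4 (0.16 log units; within the scatter) as its step. This position therefore takes a ring with one hetero atom and one hydrogen-bond acceptor without a shift that stands clear of the scatter. Nothing shown gives a reason for this result.

Open, going by these compounds, is how an amine or a carboxylic acid on this ring would read in this assay. Also open, on these data alone, is whether pyridin-4-yl gives a similar step in place of the substituted rings of compound 1 and compound 3.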